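This account rests on a few compounds, and the source may have more. Where it says the series, first, only, none or still open, it means among the compounds named here.

In a physicochemical assay for lipophilicity, using the shake flask method, in phosphate buffer, measured as octanol-water partition, with a stated time of 30 min, at pH 7.4 (on this read-out higher numbers stand for higher lipophilicity and lower numbers for lower lipophilicity), compound 1 `CN(c1ncco1)c1cnc(NCc2c(F)ccc3c2CCO3)n2cnnc12` gives 2.1. This is level with compound 2 `Cc1nccn1-c1cnc(NCc2c(F)ccc3c2CCO3)c2cn[nH]c(=O)c12` at 2.1, and compound 3 `Cc1nc(CO)ccc1-c1cnc(NCc2c(F)ccc3c2CCO3)c2cn[nH]c(=O)c12` at 2.4 stays within the usual scatter of both. Compound 4 `CN(c1ccccc1)c1cnc(NCc2c(F)ccc3c2CCO3)n2cnnc12` keeps the rest of compound 1 but has phenyl in place of 1,3-oxazol-2-yl on a nitrogen on an aromatic ring. Within the data shown here, the only measured step, a number 0.30 log units higher from compound 2 to compound 3 (within the scatter), exchanges different groups on a different core and stays within the scatter, so it offers only a loose guide. Among the measured compounds shown here, no measured pair makes this exchange, so the expectation rests on the counted change alone. An upward move beyond the scatter is expected, an estimated a number 0.80 log units higher from compound 1 to compound 4 (beyond the scatter). Compound 4 is expected at 2.9, with an estimated range of 2.4 to 3.5.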

Compound 4, distribution coefficient: 3.6
The estimate for compound 4 lay 0.70 log units below the measured number; measured number above the stated range.
By their numbers in this assay, from the lowest: compounds 1, 2 and 3 (each within the scatter of the next); then compound 4.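

Changing methyl(1,3-oxazol-2-yl)amino to methyl(phenyl)amino gives a number 1.50 log units higher from compound 1 to compound 4 (beyond the scatter) in this assay. Among these compounds, this is the first step here beyond the scatter, so a single exchange at this place on the shared core can move the read-out far more than the earlier compounds showed. Nothing measured here explains the size of this step.

Still open, on these data alone, is whether a phenyl ring carrying an amine or a carboxylic acid would stay nearer compound 4 or compound 1. One pair also cannot show whether the same exchange gives a similar step on another core.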